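Adding a Methoxy Group to Compound 1

The source may report more compounds than this note shows. Statements on the series, on what has been measured and on what is new or still open speak of the compounds shown alone.

In a functional assay on MDA-MB-231 cells (Homo sapiens) for cytotoxicity, read by MTT assay, with a stated time of 48 h (a lower number here means a stronger inhibitor, a higher number a weaker inhibitor), the measured compounds are:

compound 1 `O=C(/C=C/c1ccc2c(c1)B(O)OC2)c1ccccc1` gives 2300 nM
compound 2 `O=C(/C=C/c1ccc2c(c1)B(O)OC2)c1ccc([N+](=O)[O-])cc1` gives 11200 nM
compound 3 `O=C(/C=C/c1ccc2c(c1)B(O)OC2)c1cccc(F)c1` gives 3000 nM

Compound 1 has the lowest number of the three. Its nearest neighbour is compound 3, with a 1.3-fold higher number from compound 1 to compound 3 (0.12 log units; within the scatter), a gap within the scatter, so these two cannot be told apart. Its furthest is compound 2, with a 4.9-fold higher number from compound 1 to compound 2 (0.69 log units; beyond the scatter), a gap beyond the scatter.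

Compound 4 `COc1ccccc1C(=O)/C=C/c1ccc2c(c1)B(O)OC2` differs from compound 1 by methoxy in place of hydrogen on an aromatic carbon. The two measured steps bear on it only loosely: both also add a group to the same ring, yet neither adds a methoxy, and neither sits ortho to a large group. The nitro gave a modest weakening, the fluoro no change beyond the scatter. The shared core is left untouched in all four compounds.

On this thin basis, a small step upward in this assay, or none beyond the scatter, is expected, namely a 1.5-fold higher number from compound 1 to compound 4 (0.18 log units; within the scatter). Compound 4 is therefore estimated at 3500 nM, within a range from 1500 nM to 8000 nM.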

Compound 4, half-maximal inhibitory concentration: 3100 nM
The estimate for compound 4 lay 1.1-fold (0.05 log units) above the measured number; low and high end bracket the measured number.
By their numbers in this assay, from the lowest: compounds 1, 3 and 4 (each within the scatter of the next); then compound 2.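

In this assay, methoxy in place of hydrogen on an aromatic carbon gives a 1.3-fold higher number from compound 1 to compound 4 (0.13 log units; within the scatter) and so leaves the number within the scatter, even though the group sits ortho to a large group. Among the compounds shown here, neither the nitro nor the fluoro sat at such a place, so this is the first sign that a small group can stand there without a clear loss of cytotoxicity, though it rests on one compound. No measurement shown here explains why the number holds at this place.

An amine, a carboxylic acid or a longer chain such as butoxy at this same place could give a very different number, and the compounds shown do not settle that. Going by these compounds, whether methoxy would give a similar number elsewhere on this ring also stays open.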